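The source may report more compounds than this note shows. Statements on the series, on what has been measured and on what is new or still open speak of the compounds shown alone.

Working notes on the series. Compound 1 `COc1ccc(Oc2ccc3cc(NC(=O)c4ccc(OC(C)=O)c(CC=C(C)C)c4)c(=O)oc3c2C)cc1` gives 18200 nM in a functional assay on MCF7 cells (Homo sapiens) for antiproliferative activity; on this read-out lower numbers stand for stronger inhibition and higher numbers for weaker inhibition. Among the measured compounds shown here, compound 2 `CC(=O)Oc1ccc(C(=O)Nc2cc3ccc(Oc4ccc(C(C)(C)C)cc4)c(C)c3oc2=O)cc1CC=C(C)C` gives 75000 nM in this assay and stands at the highest of the two numbers measured so far; the step from it, a 4.1-fold higher number from compound 1 to compound 2 (0.61 log units; beyond the scatter), separates it from compound 1, its only neighbour.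

Compound 3 `COc1ccc(Nc2ccc3cc(NC(=O)c4ccc(OC(C)=O)c(CC=C(C)C)c4)c(=O)oc3c2C)cc1` is not yet measured. Its change from compound 2 is (4-methoxyphenyl)amino in place of 4-(tert-butyl)phenoxy on an aromatic carbon. This change has two parts. The first, the return from tert-butyl to methoxy on the pendant ring, runs the measured step of a 4.1-fold higher number from compound 1 to compound 2 (0.61 log units; beyond the scatter) backwards, so a drop of about that size is expected. For the measured compounds named here, the second, the swap of the linking oxygen for a linking nitrogen carrying a hydrogen, has no counterpart among the measured compounds, so its direction and size cannot be read from the data, and it widens the range rather than moving the middle.

For compound 3 a step of a 3.8-fold lower number from compound 2 to compound 3 (0.57 log units; beyond the scatter) is therefore expected in this assay, landing near compound 1. The estimate for compound 3 is 20000 nM, with a range from 6000 nM to 70000 nM.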

Compound 3, half-maximal inhibitory concentration: > 100000 nM
Compound 3 ended at the assay's limit; the forecaster's own chance of this, stated with the estimate: 10%; middle value at least 5.0-fold (0.69 log units) from the limit.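

In this assay the reading for compound 3 is a limit of the assay and not a number: the limit of > 100000 nM in this assay, at which 1 of the 3 values shown sits.

Compound 3 differs from compound 1 only in the link to the pendant ring, with (4-methoxyphenyl)amino in place of 4-methoxyphenoxy, and this single change gives an at least 5.4-fold higher number from compound 1 to compound 3 (0.73 log units; beyond the scatter), so on this aromatic carbon, ortho to a methyl group, the linking nitrogen carrying a hydrogen does not keep the level of the linking oxygen, a point the earlier pair, which changed only the group on the pendant ring, could not address. Against the tert-butyl ether the reading is an at least 1.3-fold higher number from compound 2 to compound 3 (0.12 log units; that floor lies within the scatter), a floor only, which leaves the true distance between these two compounds unsettled.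

How far compound 3 lies past the limit cannot be told, so the effect of the link is known only as a lower bound. As far as these compounds go, whether that effect goes with the hydrogen on the linking nitrogen or with the nitrogen itself stays open, and a methylamino link or a sulfur link at this position would help to separate the two.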